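The source may hold more compounds than are shown below. What is called first, only, known or untested is meant among the compounds shown, and "the series" means these compounds.

Of the compounds shown here, three sharing one core have been tested in a functional assay on MCF7 cells (Homo sapiens) for inhibition, read by MTT assay; on this read-out higher numbers stand for weaker inhibition and lower numbers for stronger inhibition. Compound 1 `COc1cc2ncnc(Nc3ccc(NC(=O)c4cccc(C)c4)cc3)c2cc1OC` gives 13000 nM. Compound 2 `CCc1ccc(C(=O)Nc2ccc(Nc3ncnc4cc(OC)c(OC)cc34)cc2)cc1` gives 65000 nM, while compound 3 `COc1cc2ncnc(Nc3ccc(NC(=O)c4ccc(F)cc4)cc3)c2cc1OC` gives 27000 nM, the second highest of the three numbers. All the steps among them were modest: a 5.0-fold higher number from compound 1 to compound 2 (0.70 log units; beyond the scatter), a 2.1-fold higher number from compound 1 to compound 3 (0.32 log units; beyond the scatter) and a 2.4-fold lower number from compound 2 to compound 3 (0.38 log units; beyond the scatter). Compound 4 `COc1cc2ncnc(Nc3ccc(NC(=O)c4ccccc4I)cc3)c2cc1OC` differs from compound 3 in one place: 2-iodophenyl in place of 4-fluorophenyl on a carbonyl carbon. The measured steps only swap one phenyl for another, and none involves an iodine or a 2-iodophenyl, so they give a rough guide at best: a modest change in this assay, with no clear direction. Compound 4 is therefore expected to give 20000 nM, with a range from 6000 nM to 70000 nM, which would be an expected step of a 1.4-fold lower number from compound 3 to compound 4 (0.13 log units; within the scatter).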

Compound 4, half-maximal inhibitory concentration: 37000 nM
Estimate against measurement, compound 4: 1.9-fold (0.27 log units) below; the measured number falls inside the stated range.
By their numbers in this assay, from the lowest: compound 1; then compounds 3, 4 and 2 (each within the scatter of the next, the first and the last beyond it).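

In this assay, 2-iodophenyl on the carbonyl carbon, the first iodine in the series, stays close to two of the earlier groups (a 1.4-fold higher number from compound 3 to compound 4 (0.14 log units; within the scatter); a 1.8-fold lower number from compound 2 to compound 4 (0.24 log units; within the scatter)). Only the 3-methylphenyl of compound 1 stands apart (a 2.8-fold higher number from compound 1 to compound 4 (0.45 log units; beyond the scatter)). No available evidence accounts for these numbers.

The step from compound 3 changes both the halogen and its printed ring position, so 4-iodophenyl or 2-fluorophenyl would be needed to separate the two. On these data alone, whether an amine or a carboxylic acid on this phenyl would shift the number also remains open.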